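Methyl on the vinyl group of compound 3

This account rests on a few compounds, and the source may have more. Where it says the series, first, only, none or still open, it means among the compounds named here.

In a functional assay on Ishikawa cells (Homo sapiens) for antiproliferative activity, read by CCK-8 assay, with a stated time of 48 h (on this read-out higher numbers stand for weaker inhibition and lower numbers for stronger inhibition), compound 3 `C=CC(=O)NCCOc1ccc(Oc2c(-c3ccc(F)cc3)sc3cc(O)ccc23)cc1` reads > 25000 nM, which is a limit and not a number. Compound 3 sits at the limit of > 25000 nM in this assay, at which 2 of the 3 values shown sit. Compound 2 `CNC(=O)/C=C/CN1CC(Oc2ccc(Oc3c(-c4ccc(F)cc4)sc4cc(O)ccc34)cc2)C1` reads > 25000 nM, also a limit. Compound 1 `O=C(/C=C/CNCCOc1ccc(Oc2c(-c3ccc(F)cc3)sc3cc(O)ccc23)cc1)N1CCCC1` gives 11300 nM. Compound 4 `C=C(C)C(=O)NCCOc1ccc(Oc2c(-c3ccc(F)cc3)sc3cc(O)ccc23)cc1` has methyl in place of hydrogen on a double-bonded chain carbon bound to a carbonyl carbon. Among the measured compounds shown here, no measured step makes this change. The nearest evidence is an at least 2.2-fold higher number from compound 1 to compound 3 (0.34 log units; beyond the scatter), a swap of the whole group on an amine nitrogen, and a step that the two limits leave unreadable from compound 2 to compound 3. In this assay, no step beyond the scatter is expected, and the estimate is a step that the limit leaves unreadable from compound 3 to compound 4. Compound 4 is expected at 30000 nM, within an estimated range of 12000 nM to 80000 nM.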

Compound 4, half-maximal inhibitory concentration: > 25000 nM
Compound 4: only a limit was reported; the forecaster's own chance of this, stated with the estimate: 75%; the middle value does not contradict the limit.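

In this assay compound 4 gives > 25000 nM, a limit and not a number. Methyl on the double-bonded chain carbon bound to a carbonyl carbon therefore does not bring this acrylamide-type chain off the limit: the limit of > 25000 nM in this assay, at which 3 of the 4 values shown sit. The one readable step is an at least 2.2-fold higher number from compound 1 to compound 4 (0.34 log units; beyond the scatter), while the steps among the compounds held at the limit cannot be read.

From the compounds shown here alone, whether methyl shifts activity at all remains open, since compound 3 and compound 4 both sit at a limit. Also open, going by these compounds, is whether a dimethylaminomethyl group on that same carbon would give a number within range.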